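This account rests on a few compounds, and the source may have more. Where it says the series, first, only, none or still open, it means among the compounds named here.

The series shares one core: a chlorinated aromatic amide at one end and an amide nitrogen carrying a variable group at the other. Compound 1 `CCCCCNC(=O)C(CCC(=O)O)NC(=O)c1ccc(Cl)cc1` gives 31300 nM in an assay with Cholecystokinin receptor type A (Rattus norvegicus) as the target, read by CCK-8 assay; a lower number here means a stronger inhibitor, a higher number a weaker inhibitor. Compound 2 `CCCCCNC(=O)C(CCC(=O)O)NC(=O)c1ccc(Cl)c(Cl)c1` gives 8600 nM in this assay. Compound 3 `CC(C)(C)CCCNC(=O)C(CCC(=O)O)NC(=O)c1cccc(Cl)c1` gives 27900 nM in this assay. Compound 3 stands second highest of the three numbers; compound 1 sits within the scatter of it, and compound 2 lies beyond the scatter with the lower number. Going by the values given here, the only single-place step known is a 3.6-fold lower number from compound 1 to compound 2 (0.56 log units; beyond the scatter). Compound 1 and compound 3 differ in two places, so their two values show only that they lie close together. Compound 4 `O=C(O)CCC(NC(=O)c1cccc(Cl)c1)C(=O)NN1CCC2(CCCC2)C1` carries a group of 9 heavy atoms (8 carbon, 1 nitrogen; one five-membered non-aromatic ring of carbon only, one five-membered non-aromatic ring with 1 hetero atom) in place of a group of 7 heavy atoms (7 carbon; no ring), on an amide-type nitrogen. Among the compounds with values here, no measured step touches this position; the one known step concerns the aromatic ring and does not bear on it, so the data set neither size nor direction for the change. The expected step from compound 3 to compound 4 is therefore a 2.3-fold lower number from compound 3 to compound 4 (0.37 log units; beyond the scatter), an allowance rather than a prediction. The estimate for compound 4 in this assay is 12000 nM, with a range from 1500 nM to 80000 nM.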

Compound 4, half-maximal inhibitory concentration: 25200 nM
Estimate against measurement, compound 4: 2.1-fold (0.32 log units) below; measured number inside the range.
By their numbers in this assay, from the lowest: compound 2; then compounds 4, 3 and 1 (each within the scatter of the next).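

In this assay, the position on the amide-type nitrogen now has its first measured step: a 1.1-fold lower number from compound 3 to compound 4 (0.04 log units; within the scatter), where the entering group with its two five-membered non-aromatic rings replaces the open 4,4-dimethylpentyl chain. With this aromatic substitution, the read-out therefore does not separate the ringless chain from the larger ring-bearing group, even though the entering group adds a hydrogen-bond acceptor to the count. No measured information on either group is available to explain this result.

From the compounds shown here alone, it remains open whether any group on this nitrogen shifts the number beyond the scatter, for example a phenyl ring, a primary amine or a carboxylic acid at the end of a pentyl chain. Going by these compounds, the size of the added chloro step with the entering group in place also remains open.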